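Compound 3 to compound 4: one added methoxy

This account rests on a few compounds, and the source may have more. Where it says the series, first, only, none or still open, it means among the compounds named here.

In an ADME assay on HEK293 cells (Homo sapiens) for cytotoxicity, read by MTT assay, with a stated time of 48 h (on this read-out higher numbers stand for weaker inhibition and lower numbers for stronger inhibition), compound 1 `COc1ccc(-c2nc(SCC(=O)c3sc(-c4ccccc4)nc3C)nc(N)c2C#N)cc1` has no numerical result, its entry being "not determined" (no result reported). Compound 2 `COc1ccc(-c2nc(C)c(C(=O)CSc3nc(-c4cccc(OC)c4)c(C#N)c(=O)[nH]3)s2)cc1` gives 95400 nM, and compound 3 `COc1cccc(-c2nc(SCC(=O)c3sc(-c4ccccc4)nc3C)[nH]c(=O)c2C#N)c1` gives 90200 nM. Among the measured compounds shown here, these two values lie within the scatter of each other, so compound 3 stands level with the only other compound that has a number.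

Compound 4 `COc1ccc(-c2nc(SCC(=O)c3sc(-c4ccccc4)nc3C)[nH]c(=O)c2C#N)cc1OC` turns the 3-methoxyphenyl of compound 3 into 3,4-dimethoxyphenyl: methoxy in place of hydrogen on an aromatic carbon. The new methoxy stands ortho to a methoxy group and para to a large group. For the measured compounds named here, one measured step bears on this change, and only indirectly: a 1.1-fold lower number from compound 2 to compound 3 (0.02 log units; within the scatter). That step is hydrogen in place of methoxy on an aromatic carbon, at another place in the molecule. Going by the values given here, no measured pair tests a methoxy on the ring that changes here. No shift beyond the scatter is therefore expected in this assay, and the expected step is a 1.0-fold lower number from compound 3 to compound 4 (0.00 log units; within the scatter). Compound 4 is estimated at 90000 nM, with an expected range of 50000 nM to 160000 nM.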

Compound 4, half-maximal inhibitory concentration: 91800 nM
Estimate against measurement, compound 4: 1.0-fold (0.01 log units) below; measured number inside the range.
By their numbers in this assay, from the lowest: compounds 3, 4 and 2 (each within the scatter of the next).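

In this assay, among the compounds shown here, the change from 3-methoxyphenyl to 3,4-dimethoxyphenyl gives a 1.0-fold higher number from compound 3 to compound 4 (0.01 log units; within the scatter) and is the first measured step on this ring. The new methoxy, ortho to a methoxy group and para to a large group, therefore produces no shift beyond the scatter. Together with a 1.1-fold lower number from compound 2 to compound 3 (0.02 log units; within the scatter) at another place in the molecule, exchange between methoxy and hydrogen has now been read at two places, and neither step lies beyond the scatter; no measured evidence bears on why these steps are so small.

Open, as far as these compounds go, is whether a different kind of group at this place on the ring, such as an amine or a carboxylic acid, would move the number beyond the scatter. The compounds with numbers all lie within the scatter of one another, so they do not show which parts of the structure can shift this read-out.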